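This account rests on a few compounds, and the source may have more. Where it says the series, first, only, none or still open, it means among the compounds named here.

Within the data shown here, compound 1 `CC(C)[C@H](NC(=O)COc1cccc2ccccc12)C(=O)N[C@@H](CC(=O)O)C(=O)COc1ccc(C(F)(F)F)cc1` is one of two compounds measured in a functional assay with Homo sapiens as the target; on this read-out higher numbers stand for weaker inhibition and lower numbers for stronger inhibition. In this assay, among the measured compounds shown here, compound 1 gives 12300 nM, and the only other measured compound, compound 2 `CC(C)[C@H](NC(=O)COc1cccc2ccccc12)C(=O)N[C@@H](CC(=O)O)C(=O)COc1ccc(Oc2ccccc2)cc1`, gives 19000 nM. The step between them is a 1.5-fold higher number from compound 1 to compound 2 (0.19 log units; within the scatter), so the two numbers cannot be told apart, and compound 1 stands level with compound 2 rather than clearly apart from it. Compound 3 `CC(C)[C@H](NC(=O)COc1cccc2ccccc12)C(=O)N[C@@H](CC(=O)O)C(=O)COc1c(F)cccc1F` has not yet been measured. It differs from compound 1 in one place: 2,6-difluorophenyl in place of 4-(trifluoromethyl)phenyl on an oxygen on a saturated carbon. For the measured compounds named here, the single measured step, a 1.5-fold higher number from compound 1 to compound 2 (0.19 log units; within the scatter), also rebuilds the aromatic group on that same oxygen, though it exchanges a different part of the ring, and it stayed within the scatter. No measured step tests the exact exchange that leads to compound 3, so nothing shown gives grounds to expect a large move in either direction, and the outcome is uncertain. Compound 3 is thus expected to show only a modest shift, a 1.2-fold higher number from compound 1 to compound 3 (0.09 log units; within the scatter), with a wide range allowed. For compound 3 the estimated value in this assay is 15000 nM, with a range from 5000 nM to 45000 nM.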

Compound 3, half-maximal inhibitory concentration: > 100000 nM
Compound 3 was reported as a limit; the forecaster's own chance of this, stated with the estimate: 10%; middle value at least 6.6-fold (0.82 log units) from the limit.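

In this assay, the exchange of 4-(trifluoromethyl)phenyl for 2,6-difluorophenyl on this oxygen gives an at least 8.1-fold higher number from compound 1 to compound 3 (0.91 log units; beyond the scatter). For compound 3 the entry is a limit of the assay and not a number: the limit of > 100000 nM in this assay, at which 1 of the 3 values shown sits. Among these compounds, the only earlier change at this place gave a 1.5-fold higher number from compound 1 to compound 2 (0.19 log units; within the scatter), so that step alone could have suggested that the group on this oxygen can be rebuilt freely, whereas the new step shows that at least one exchange here costs clearly measurable inhibition, and that the outcome depends on which aromatic group is present.

This single exchange removes the trifluoromethyl group and adds two fluorines at once, so the compounds shown cannot say which of these two parts accounts for the loss, and a plain phenyl or a phenyl carrying a single fluorine would be needed to separate them. They also leave open why inhibition is lost, and whether other groups on the ring, such as a methoxy or a chlorine, would be tolerated as well as trifluoromethyl and phenoxy.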